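A few compounds are considered here, and "the series" means these few. Any claim that something is new, unique, unknown or untested is made for them only; others in the source may bear on it.

In an assay on cells for inhibition of Amine oxidase [flavin-containing] A (Homo sapiens) (a lower number here means a stronger inhibitor, a higher number a weaker inhibitor), compound 3 `O=C(Nc1ccc(F)c(Cl)c1)c1ccc2cn[nH]c2c1` gives only a limit of the assay, > 10000 nM. Compound 1 `O=C(Nc1ccc2[nH]ncc2c1)c1c(F)cccc1Cl` likewise gives only a limit in this assay, > 10000 nM. Compound 2 `COc1ccc(NC(=O)c2ccc3[nH]ncc3c2)cc1OC` also gives only a limit there, > 10000 nM. All three values sit at the same boundary, (the limit of > 10000 nM in this assay, at which 3 of the 3 values shown sit), so compound 3 cannot be ranked against the other two on these numbers. Compound 4 `O=C(Nc1ccc(F)c(F)c1)c1ccc2cn[nH]c2c1` differs from compound 3 by fluoro in place of chloro on an aromatic carbon. Among the measured compounds shown here, no measured pair shows what this change does in this assay. Compound 4 is expected to remain at the limit as well, with the step that the limit leaves unreadable from compound 3 to compound 4 expected to stay within the usual scatter. The estimate for compound 4 in this assay is 15000 nM, in the range 5000 nM to 50000 nM.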

Compound 4, half-maximal inhibitory concentration: > 10000 nM
Compound 4 ended at the assay's limit; the forecaster's own chance of this, stated with the estimate: 85%; the middle value lies beyond the limit too.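

Compound 3 and compound 4 both end at a limit in this assay, so swapping chloro for fluoro gives no readable step: the limit of > 10000 nM in this assay, at which 4 of the 4 values shown sit. The compounds shown leave open whether any close relative gives a measurable value in this assay.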